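The source may hold more compounds than are shown below. What is called first, only, known or untested is meant among the compounds shown, and "the series" means these compounds.

Among the compounds with values here, compound 2 `c1ccc2c(c1)CN[C@@H](CN(CCCCNCC1CCOCC1)[C@H]1CCCc3cccnc31)C2` is the one compound in this set with a measured number: in a functional assay on cells for antagonist activity at C-X-C chemokine receptor type 4 (Homo sapiens), read by fluorescence and calcium flux, with stated times of 25 min and 90 s (on this read-out higher numbers stand for weaker inhibition and lower numbers for stronger inhibition), compound 2 gives 52.9 nM. Within the data shown here, the only other value is a limit. Compound 1 `c1ccc(CN(CCCCN(C[C@H]2Cc3ccccc3CN2)[C@H]2CCCc3cccnc32)Cc2ccccc2)cc1` is reported in this assay only as a limit, > 16700 nM, so no number is known for it; this is the limit of > 16700 nM in this assay, at which 1 of the 2 values shown sits. Compound 2 therefore stands alone as the single point from which an expectation can be built.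

The unmeasured compound 3 `CC(C)(CCN)CN(C[C@H]1Cc2ccccc2CN1)[C@H]1CCCc2cccnc21` differs from compound 2 in one place. The change is a group of 6 heavy atoms (5 carbon, 1 nitrogen; no ring) in place of a group of 11 heavy atoms (9 carbon, 1 nitrogen, 1 oxygen; one six-membered non-aromatic ring with 1 hetero atom), on a saturated chain carbon bound to an amine nitrogen. Both compounds keep the shared core, and the basic amine that carries the changed group remains in both.

Among the measured compounds shown here, no measured step is available to say how such a change plays out in this assay. The shorter chain of compound 3 still ends in an amine, so a modest weakening, somewhat beyond the usual scatter, is expected rather than a large loss. The estimated step from compound 2 to compound 3 is a 2.3-fold higher number from compound 2 to compound 3 (0.36 log units; beyond the scatter). Compound 3 is expected to give about 120 nM, within a range from 30 nM to 500 nM.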

Compound 3, half-maximal inhibitory concentration: > 33300 nM
Compound 3: a limit, no number; the forecaster's own chance of this, stated with the estimate: 10%; middle value at least 270-fold (2.44 log units) away from the limit.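

Until now, nothing measured showed how much the group on a saturated chain carbon bound to an amine nitrogen matters in this assay. Compound 3 is reported only as a limit, not as a number: the limit of > 33300 nM in this assay, at which 1 of the 3 values shown sits.

Even so, the result can be read as a lower bound on the size of the change, an at least 620-fold higher number from compound 2 to compound 3 (2.79 log units; beyond the scatter), so replacing the group of 11 heavy atoms and its six-membered non-aromatic ring with the group of 6 heavy atoms and no ring is far from a minor edit at this place. It also shows that a chain ending in an amine is not enough on its own to keep a measurable number in this assay.

This single step changes the ring, the length and the branching of the chain all at once, so the compounds shown cannot say which of these differences accounts for the loss, and they give no reason for it. On these data alone, it remains open whether an unbranched chain ending in an amine, or a cyclohexyl ring in place of the ring with its hetero atom, would keep the value of compound 2 (52.9 nM).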